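The compounds below may be only part of what the source reports. "The series", "measured", "known", "first", "only" and "open" are said of these compounds alone.

Working notes on the series. Among the measured compounds shown here, in an ADME assay on a cell-free system (serum, Rattus norvegicus) for protein binding, read by LC-MS, using equilibrium dialysis, with a stated time of 24 h (on this read-out higher numbers stand for a larger free fraction and lower numbers for a smaller free fraction), compound 1 (`CC(C)N1CN(C(c2ccccc2)c2ccccc2)n2ccc(=O)c(O)c2C1=O`) gives 0.0377 and compound 2 (`O=C1c2c(O)c(=O)ccn2N(C(c2ccccc2)c2ccccc2)CN1Cc1ccco1`) gives 0.0217, so compound 2 stands within the scatter of the only other measured compound. Compound 3 (`CN1CN(C(c2ccccc2)c2ccccc2)n2ccc(=O)c(O)c2C1=O`) is the next case, with this difference from compound 2: hydrogen in place of furan-2-yl on a saturated chain carbon bound to an amide-type nitrogen in a ring. In words, this is hydrogen in place of furan-2-yl on a saturated chain carbon bound to an amide-type nitrogen in a ring, or (furan-2-yl)methyl to methyl. For the measured compounds named here, one measured step bears on it, a change of the group on that nitrogen: a 1.7-fold lower number from compound 1 to compound 2 (0.24 log units; within the scatter). Read in reverse, this small step from compound 1 points only weakly towards a higher number once the (furan-2-yl)methyl group leaves, so a modest rise is expected. The expected step is a 2.3-fold higher number from compound 2 to compound 3 (0.36 log units; beyond the scatter). Compound 3 is estimated at 0.05, with an expected range of 0.025 to 0.1.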

Compound 3, unbound fraction: 0.07
For compound 3 the middle estimate is 1.4-fold (0.15 log units) below the measured one, and the stated range covers the measured number.
By their numbers in this assay, from the lowest: compounds 2, 1 and 3 (each within the scatter of the next, the first and the last beyond it).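

Cutting (furan-2-yl)methyl back to methyl gives a 3.2-fold higher number from compound 2 to compound 3 (0.51 log units; beyond the scatter) in this assay and is the first change on this amide-type nitrogen in a ring to lie beyond the scatter. Methyl in place of isopropyl gives only a 1.9-fold higher number from compound 1 to compound 3 (0.27 log units; within the scatter) and so stays within it; with compound 1 also within the scatter of compound 2, only the methyl and (furan-2-yl)methyl compounds are resolved from each other. No measurement on hand accounts for this difference.

The three compounds cannot separate any role of the furan ring from that of the overall size of the group. On these data alone, a benzyl group, a longer alkyl chain and a chain ending in an amine or a carboxylic acid remain open at this place.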